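This account rests on a few compounds, and the source may have more. Where it says the series, first, only, none or still open, it means among the compounds named here.

Measured compounds:
- compound 1 `COc1ccc(CNC(=O)c2cc(Oc3ccc(/C=C/c4ccccn4)cc3)ccn2)cc1` gives 63600 nM in a functional assay on A549 cells (Homo sapiens) for antiproliferative activity, read by CCK-8 assay, with a stated time of 48 h; on this read-out higher numbers stand for weaker inhibition and lower numbers for stronger inhibition
- compound 2 `O=C(Nc1ccccc1)c1cc(Oc2ccc(/C=C/c3ccncc3)cc2)ccn1` gives 79700 nM in this assay
- compound 3 `COc1ccc(CNC(=O)c2cc(Oc3ccc(/C=C/c4ccncc4)cc3)ccn2)cc1` gives 19300 nM in this assay

Compound 3 carries the lowest of the three numbers, set apart from both others by steps beyond the scatter: a 3.3-fold lower number from compound 1 to compound 3 (0.52 log units; beyond the scatter) and a 4.1-fold lower number from compound 2 to compound 3 (0.62 log units; beyond the scatter). The shared core of all three holds a carbonyl with a variable substituent on its amide-type nitrogen, and the second of these steps shows that this substituent moves the number in this assay by a modest amount.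

Compound 4 `O=C(c1cc(Oc2ccc(/C=C/c3ccncc3)cc2)ccn1)N1CCCC1` differs from compound 3 in one place: pyrrolidin-1-yl in place of (4-methoxybenzyl)amino on a carbonyl carbon. Among the compounds with values here, only the step of a 4.1-fold lower number from compound 2 to compound 3 (0.62 log units; beyond the scatter) bears on this, and it concerns a different exchange at the same position; no measured pair shows the loss of the amide hydrogen or a ring closed on the nitrogen. Since the 4-methoxybenzyl group gave the lowest number seen, its removal is expected to move the number upward by a modest step, with wide uncertainty. Compound 4 is therefore expected to give about 45000 nM in this assay, between 12000 nM and 150000 nM. The expected step is a 2.3-fold higher number from compound 3 to compound 4 (0.37 log units; beyond the scatter).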

Compound 4, half-maximal inhibitory concentration: 18600 nM
Estimate against measurement, compound 4: 2.4-fold (0.38 log units) above; the range from low to high includes it.
By their numbers in this assay, from the lowest: compounds 4 and 3 (each within the scatter of the next); then compounds 1 and 2 (each within the scatter of the next).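

On the carbonyl carbon, pyrrolidin-1-yl in place of (4-methoxybenzyl)amino gives a 1.0-fold lower number from compound 3 to compound 4 (0.02 log units; within the scatter) in this assay, so in this pair the number holds without the aromatic ring of the 4-methoxybenzyl group and without the amide hydrogen. Pyrrolidin-1-yl in place of anilino gives a 4.3-fold lower number from compound 2 to compound 4 (0.63 log units; beyond the scatter), so the gap seen earlier at this position does not depend on the 4-methoxybenzyl group, and among the three substituents with the pyridin-4-yl end, anilino alone stands apart. No measured evidence on the cause of these steps is available.

On these data alone, whether morpholin-4-yl, piperidin-1-yl or an open-chain dimethylamino group on the carbonyl carbon stays at this level remains open. Also open, as far as these compounds go, is whether pyridin-2-yl in place of pyridin-4-yl shifts the number to the same extent with pyrrolidin-1-yl on the carbonyl carbon.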